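From pyridin-3-yl to pyridin-4-yl in compound 4

The compounds below may be only part of what the source reports. "The series", "measured", "known", "first", "only" and "open" are said of these compounds alone.

Compound 1 `CC(=O)N1N=C(c2ccc3ccccc3c2)OC1c1ccc(Cl)cc1` gives 2.48 ug/mL in a functional assay on B16-F10 cells (Mus musculus) for antiproliferative activity, read by MTT assay, with a stated time of 48 h; on this read-out lower numbers stand for stronger inhibition and higher numbers for weaker inhibition
Compound 2 `CC(=O)N1N=C(c2ccc3ccccc3c2)OC1c1ccc(F)cc1` gives 4.65 ug/mL in this assay
Compound 3 `CC(=O)N1N=C(c2ccc3ccccc3c2)OC1c1cccnc1` gives 3.06 ug/mL in this assay

All three values lie within the scatter of one another, so compound 3 at 3.06 ug/mL holds no clear rank among them. Compound 4 `CC(=O)N1N=C(c2ccc3ccccc3c2)OC1c1ccncc1` differs from compound 3 by a single change pyridin-4-yl in place of pyridin-3-yl on a saturated ring carbon. Within the data shown here, no measured step tests this exchange directly. The closest evidence comes from exchanges at that same carbon, namely a 1.2-fold higher number from compound 1 to compound 3 (0.09 log units; within the scatter) and a 1.5-fold lower number from compound 2 to compound 3 (0.18 log units; within the scatter) and both stay within the scatter. No step beyond the scatter is therefore expected in this assay for this change. The estimate amounts to a 1.0-fold lower number from compound 3 to compound 4 (0.01 log units; within the scatter) as the expected step. Compound 4 is expected at 3 ug/mL with an estimated range from 1.4 ug/mL to 6.5 ug/mL around that figure.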

Compound 4, half-maximal inhibitory concentration: 2.97 ug/mL
Estimate against measurement, compound 4: 1.0-fold (0.00 log units) above; the range from low to high includes it.
By their numbers in this assay, from the lowest: compounds 1, 4, 3 and 2 (each within the scatter of the next).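

In this assay, the exchange of pyridin-3-yl for pyridin-4-yl at this saturated ring carbon is now tested directly (a 1.0-fold lower number from compound 3 to compound 4 (0.01 log units; within the scatter)), and the two groups cannot be told apart. Pyridin-4-yl also stays level with both halogenated phenyl groups (a 1.6-fold lower number from compound 2 to compound 4 (0.19 log units; within the scatter); a 1.2-fold higher number from compound 1 to compound 4 (0.08 log units; within the scatter)), so none of the four groups at this carbon separates from the others. Nothing measured on these compounds explains this.

On these data alone, whether an aliphatic amine or a carboxylic acid on the ring at this carbon would move the number beyond the scatter remains open. So does the effect of pyridin-2-yl there.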